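Swapping an Amide for a Nitrile on the Aryl Ring

This account rests on a few compounds, and the source may have more. Where it says the series, first, only, none or still open, it means among the compounds named here.

Measured so far:
Compound 1, `COCc1ccccc1C1Cc2nccn2C1`: 1.8
Compound 2, `Fc1ccccc1C1Cc2nccn2C1`: 2
Compound 3, `NC(=O)c1ccccc1C1Cc2nccn2C1`: "not determined" (no result reported)

All three compounds share the same core and differ only in the group carried on the aromatic ring. Among the measured compounds shown here, in a physicochemical assay for lipophilicity, at pH 7.4 (on this read-out lower numbers stand for lower lipophilicity and higher numbers for higher lipophilicity), compound 1 gives 1.8, while compound 2 gives 2; the one measured step is a number 0.20 log units higher from compound 1 to compound 2 (within the scatter). Compound 3 stands nowhere on these numbers: in this assay compound 3 has "not determined" (no result reported), so no value for it can anchor the next step.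

Compound 4, `N#Cc1ccccc1C1Cc2nccn2C1`, differs from compound 3 by cyano in place of carbamoyl on an aromatic carbon. For the measured compounds named here, no measured step involves either a carbamoyl or a cyano group, so the step of a number 0.20 log units higher from compound 1 to compound 2 (within the scatter) bears on this change only loosely: it shows that exchanging one small group on the same aromatic carbon for another moved the number within the scatter. On that basis compound 4 is expected to sit close to compounds 1 and 2 in this assay, with no step beyond the scatter foreseen in either direction. The estimate for compound 4 is 1.5, within a range from 1 to 2.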

Compound 4, distribution coefficient: 1.3
The estimate for compound 4 lay 0.20 log units above the measured number; the measured number falls inside the stated range.
By their numbers in this assay, from the lowest: compound 4; then compounds 1 and 2 (each within the scatter of the next).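

In this assay cyano in place of fluoro gives a number 0.70 log units lower from compound 2 to compound 4 (beyond the scatter) and cyano in place of methoxymethyl gives a number 0.50 log units lower from compound 1 to compound 4 (beyond the scatter) on the same aromatic carbon. Among the compounds shown here, the one earlier exchange on this carbon stayed within the scatter, so these are the first steps showing that the group held here can move the number beyond it. Cyano is thus set apart from both fluoro and methoxymethyl, which remain within the scatter of each other.

Where an amine or a carboxylic acid on this carbon would fall stays open, and the change from carbamoyl to cyano itself cannot be read, with compound 3 having no number. Nothing shown here gives a reason for the shift.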